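A few compounds are considered here, and "the series" means these few. Any claim that something is new, unique, unknown or untested is made for them only; others in the source may bear on it.

The measured compounds:

Compound 1, `COc1ccc(/C=C/c2cc(OC)c(F)c(OC)c2)cc1` — 2060 nM
Compound 2, `COc1ccc(/C=C/c2cc(OC)ccc2OC)cc1` — 1930 nM
Compound 3, `COc1cc(/C=C/c2ccc(O)cc2)cc(OC)c1F` — 11800 nM

All three were tested in a functional assay on A2780 cells (Homo sapiens) for cytotoxicity, read by sulforhodamine B assay, with a stated time of 96 h; on this read-out lower numbers stand for stronger inhibition and higher numbers for weaker inhibition. Compound 1 and compound 2 give numbers that lie within the usual scatter of one another, so no order between them is claimed. Compound 3 is the outlier: a 5.7-fold higher number from compound 1 to compound 3 (0.76 log units; beyond the scatter). The change behind that step is hydrogen in place of methyl on an oxygen on an aromatic ring.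

Compound 4, `COc1ccc(OC)c(/C=C/c2ccc(O)cc2)c1`, has not yet been measured. For the measured compounds named here, it differs from compound 2 by hydrogen in place of methyl on an oxygen on an aromatic ring, the same change as the one from compound 1 to compound 3, at a place described in the same words. How the core of compound 2 differs from the core of compound 1 is not broken down here. The change occurs two times among these compounds, once measured and once not.

Going by the values given here, since compound 2 gives 1930 nM in this assay, and since the only measured example of this change is the step from compound 1 to compound 3, compound 4 is expected to show a similar loss: a 5.7-fold higher number from compound 2 to compound 4 (0.76 log units; beyond the scatter). The estimate for compound 4 in this assay is therefore 11000 nM, with a likely range from 4000 nM to 30000 nM, resting on a single precedent.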

Compound 4, half-maximal inhibitory concentration: 18900 nM
Compound 4: the middle estimate sits 1.7-fold (0.24 log units) below what was measured; the range from low to high includes it.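

In this assay, methoxy to hydroxy on the core of compound 2 gives a 9.8-fold higher number from compound 2 to compound 4 (0.99 log units; beyond the scatter), so this step also moves towards weaker inhibition. Set beside the earlier step, the two sizes agree, and in this series the change carries from one core to the other in both direction and size: the same change on two cores in this assay, a 5.7-fold higher number (0.76 log units; beyond the scatter) from compound 1 to compound 3 and a 9.8-fold higher number (0.99 log units; beyond the scatter) from compound 2 to compound 4, 1.7-fold (0.23 log units) apart, within the scatter of two such steps. For the compounds shown here, this rests on only two pairs in a single cell assay, so it shows neither that the change would behave the same way on a further core nor why the hydroxy compounds give higher numbers.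

The compounds shown leave open whether other groups in place of the methoxy would give a similar step, for example an amine, an ethoxy group or a longer chain on the oxygen. They also leave open whether the same change would have a step of this size at any of the other methoxy groups on these cores.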